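The source may report more compounds than this note shows. Statements on the series, on what has been measured and on what is new or still open speak of the compounds shown alone.

Values in an ADME assay on liver for metabolic stability, with Liver microsome (Homo sapiens) as the target, read by LC-MS, using microsomes (on this read-out higher numbers stand for fast clearance and lower numbers for slow clearance), for the measured compounds:
- compound 1 (`O=C(NCc1cc(Cl)ccc1-n1cnnn1)[C@@H]1[C@H]2C[C@H]2CN1C(=O)[C@H](O)c1ccccc1`) gives 61 mL.min-1.g-1
- compound 2 (`O=C(NCc1cc(Cl)ccc1-n1cnnn1)[C@@H]1[C@H]2C[C@H]2CN1C(=O)[C@H](O)Cc1ccccc1`) gives 96 mL.min-1.g-1
- compound 3 (`O=C(NCc1cc(Cl)ccc1-n1cnnn1)[C@@H]1[C@@H]2C[C@@H]2CN1C(=O)[C@H](O)Cc1ccccc1`) gives 74 mL.min-1.g-1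

Compound 2 stands within the usual scatter of both other compounds, so these measurements do not separate it from either one. Two measured steps offer a guide. The first lengthens the chain from phenyl to benzyl (a 1.6-fold higher number from compound 1 to compound 2 (0.20 log units; within the scatter)) and is the closer guide, since it alters the same part of the molecule. The second changes only the configuration as drawn (a 1.3-fold lower number from compound 2 to compound 3 (0.11 log units; within the scatter)). Neither step goes beyond the scatter.

Compound 4 (`O=C(NCc1cc(Cl)ccc1-n1cnnn1)[C@@H]1[C@H]2C[C@H]2CN1C(=O)[C@H](O)CC1CC1`) has not yet been measured. It carries cyclopropyl in place of phenyl, so benzyl becomes cyclopropylmethyl (cyclopropyl in place of phenyl on a saturated chain carbon, two bonds along the chain from a carbonyl carbon and an oxygen on a saturated carbon). Going by the small phenyl-to-benzyl step (a 1.6-fold higher number from compound 1 to compound 2 (0.20 log units; within the scatter)), no step beyond the scatter is expected in this assay, though a slight drift towards a lower number is possible. The estimated step is small (a 1.5-fold lower number from compound 2 to compound 4 (0.17 log units; within the scatter)). For compound 4 the expected value is 65 mL.min-1.g-1, with an estimated range from 30 mL.min-1.g-1 to 120 mL.min-1.g-1.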

Compound 4, intrinsic clearance in microsomes: < 14 mL.min-1.g-1
Compound 4 was reported as a limit (the forecaster's own chance of this, stated with the estimate: 3%); middle value at least 4.6-fold (0.66 log units) from the limit.
By their numbers in this assay, from the lowest: compounds 1, 3 and 2 (each within the scatter of the next). At a limit, below all of these: compound 4.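

The phenyl-to-benzyl step and the change in configuration both stayed within the scatter, and they gave no sign that this assay would respond strongly to a change at this end of the molecule. Replacing the phenyl of the benzyl group with cyclopropyl, which gives cyclopropylmethyl, does produce a clear drop, with an at least 6.8-fold lower number from compound 2 to compound 4 (0.83 log units; beyond the scatter), and the comparison with the shorter phenyl compound agrees, with an at least 4.3-fold lower number from compound 1 to compound 4 (0.63 log units; beyond the scatter). Compound 4 is reported as a limit of the assay and not as a number, and both steps are minimum sizes: the limit of < 14 mL.min-1.g-1 in this assay, at which 1 of the 4 values shown sits.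

Still open, going by these compounds, is whether the drop depends on the three-membered ring itself or only on the loss of the phenyl, which a cyclobutyl, cyclohexyl or isobutyl group at the same place could help to tell. Also open, on these data alone, is whether the same swap gives a similar step on the configuration of the core drawn in compound 3.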